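Sulfonyl-bearing aryl groups on the shared core

This account rests on a few compounds, and the source may have more. Where it says the series, first, only, none or still open, it means among the compounds named here.

In an assay for binding affinity to dual specificity mitogen-activated protein kinase kinase 4 (Homo sapiens), read by KINOMEscan, tested at 100 nM (a lower number here means a stronger effect, a higher number a weaker effect of the compound at the concentration tested), three compounds were measured:
compound 1 `CCCS(=O)(=O)Nc1ccc(F)c(C(=O)c2n[nH]c3ncc(-c4cccc(Cl)c4)cc23)c1F`: 40%
compound 2 `CCCS(=O)(=O)Nc1ccc(F)c(C(=O)c2n[nH]c3ncc(-c4ccc(C(F)(F)F)cc4)cc23)c1F`: 29%
compound 3 `CCCS(=O)(=O)Nc1ccc(F)c(C(=O)c2n[nH]c3ncc(-c4ccc(S(C)(=O)=O)cc4)cc23)c1F`: 1.5%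

Compound 3 stands lowest of the three in this assay, with compound 2 nearest and compound 1 furthest, both beyond the scatter. The steps are a number 11 percentage points lower from compound 1 to compound 2 (beyond the scatter), a number 38.5 percentage points lower from compound 1 to compound 3 (beyond the scatter) and a number 27.5 percentage points lower from compound 2 to compound 3 (beyond the scatter). Compound 4 `CCCS(=O)(=O)Nc1ccc(F)c(C(=O)c2n[nH]c3ncc(-c4ccc(S(N)(=O)=O)cc4Cl)cc23)c1F` differs from compound 3 by 2-chloro-4-sulfamoylphenyl in place of 4-(methylsulfonyl)phenyl on an aromatic carbon. Going by the values given here, no measured step exchanges a methylsulfonyl for a sulfamoyl, and none adds a chlorine to this ring, so the only guidance is indirect: both aryl groups that carry a sulfonyl-type substituent may behave alike, and compound 3 already sits near the floor of the read-out, leaving little room for a further decrease. A step of the kind seen in a number 27.5 percentage points lower from compound 2 to compound 3 (beyond the scatter) is therefore not expected to recur; the step from compound 3 to compound 4 is expected to be a number 2.5 percentage points higher from compound 3 to compound 4 (within the scatter), within the scatter. Compound 4 is estimated at 4%, between 0.5% and 20%.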

Compound 4, a percentage reported as activity, at one concentration (the size of the read-out at that concentration, not a potency): 3.4%
Estimate against measurement, compound 4: 0.6 percentage points above, within the range that was stated.
By their numbers in this assay, from the lowest: compounds 3 and 4 (each within the scatter of the next); then compound 2; then compound 1.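

In this assay the exchange of 4-(methylsulfonyl)phenyl for 2-chloro-4-sulfamoylphenyl gives a number 1.9 percentage points higher from compound 3 to compound 4 (within the scatter), so at this position the low read-out is not confined to a single aryl group. The second sulfonyl-bearing group also stands clear of both aryl groups without a sulfonyl, with a number 25.6 percentage points lower from compound 2 to compound 4 (beyond the scatter) and a number 36.6 percentage points lower from compound 1 to compound 4 (beyond the scatter), and among these four compounds none goes against that division. No measurement is at hand that accounts for the division.

The chlorine and the sulfamoyl enter together, so compound 4 does not separate what each contributes. As far as these compounds go, it also remains open whether a carboxylic acid or an amine in place of the sulfonyl-type group, or a longer chain on the sulfonyl, would give a similarly low read-out.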